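A few compounds are considered here, and "the series" means these few. Any claim that something is new, unique, unknown or untested is made for them only; others in the source may bear on it.

Notes on the series, with one aromatic group varied on the shared core. In a toxicity assay on MT4 cells (Homo sapiens) for cytotoxicity, read by MTT assay, with a stated time of 5 days (a higher number here means that more compound is tolerated, a lower number that less compound is tolerated), compound 1 `Cc1cc(-c2cncnc2)cc(C)c1Nc1ccnc(Nc2ccc(C#N)cc2)n1` gives 6800 nM, compound 2 `Cc1cc(-c2cc3ccccc3s2)cc(C)c1Nc1ccnc(Nc2ccc(C#N)cc2)n1` gives 138000 nM and compound 3 `Cc1cc(-c2ccnc(C(F)(F)F)c2)cc(C)c1Nc1ccnc(Nc2ccc(C#N)cc2)n1` gives 6100 nM. Compound 3 thus stands at the low end of the three numbers, level with its nearest neighbour: a 1.1-fold lower number from compound 1 to compound 3 (0.05 log units; within the scatter). The 1-benzothiophen-2-yl group stands apart, with a 20-fold higher number from compound 1 to compound 2 (1.31 log units; beyond the scatter) and a 23-fold lower number from compound 2 to compound 3 (1.35 log units; beyond the scatter).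

Compound 4 `Cc1ncc(-c2cc(C)c(Nc3ccnc(Nc4ccc(C#N)cc4)n3)c(C)c2)cn1` is the next entry: 2-methylpyrimidin-5-yl in place of 2-(trifluoromethyl)pyridin-4-yl on an aromatic carbon. In words, 2-methylpyrimidin-5-yl comes in place of 2-(trifluoromethyl)pyridin-4-yl on an aromatic carbon. The entering group is one six-membered aromatic ring, as are the groups of compound 1 and compound 3, so the small step between those two is the one that bears most directly. For the measured compounds named here, the two large steps involve the 1-benzothiophen-2-yl group of compound 2, which has no counterpart in this change, and they carry little weight here. The nearest measured group is the pyrimidin-5-yl of compound 1, which gives 6800 nM.

The estimated step is a 1.2-fold higher number from compound 3 to compound 4 (0.09 log units; within the scatter), which is expected to stay within the scatter. Compound 4 is estimated at 7500 nM, with an expected range of 3000 nM to 20000 nM.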

Compound 4, half-maximal cytotoxic concentration: 3900 nM
The estimate for compound 4 lay 1.9-fold (0.28 log units) above the measured number, within the range that was stated.
By their numbers in this assay, from the lowest: compounds 4, 3 and 1 (each within the scatter of the next); then compound 2.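

For the compounds shown here, the methyl group adds something the earlier compounds could not: a 1.7-fold lower number from compound 1 to compound 4 (0.24 log units; within the scatter) is the first step in this set that changes a substituent on one ring type, rather than replacing one ring with another, and in this assay it stays within the scatter. Going by these compounds alone, the step of a 1.6-fold lower number from compound 3 to compound 4 (0.19 log units; within the scatter) also stays within the scatter, so compounds 1, 3 and 4 form one level despite carrying different groups, with trifluoromethyl in compound 3 and methyl in compound 4; the step of a 35-fold lower number from compound 2 to compound 4 (1.55 log units; beyond the scatter) is large and beyond the scatter, which leaves the 1-benzothiophen-2-yl group of compound 2 as the only group apart from the three with one six-membered aromatic ring. No available measurement bears on why the numbers fall this way.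

The compounds shown leave open whether the separation of compound 2 belongs to its second ring or to its sulfur, a question that thiophen-2-yl and plain phenyl groups at this position would help to divide. They also leave open whether the level shared by compounds 1, 3 and 4 would hold for a six-membered aromatic ring carrying an amine or a carboxylic acid.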